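The compounds below may be only part of what the source reports. "The series", "measured", "known", "first", "only" and "open" are said of these compounds alone.

Compound 3, with the structure `Cc1nn(-c2ncnc3nc[nH]c23)c2c1C(OCc1ccccc1Cl)CC(=O)N2`, was tested in a functional assay on HEK293 cells for agonist activity at G-protein coupled receptor 39 (Homo sapiens), read by scintillation proximity assay and inositol phosphate accumulation, with a stated time of 75 min (on this read-out higher numbers stand for an effect only at larger amounts of compound and lower numbers for an effect already at smaller amounts), where compound 3 gives 47 nM. Among the three compounds measured so far it holds the second highest number. Its nearest neighbour is compound 1, `Cc1nn(-c2ncnc3nc[nH]c23)c2c1C(OCc1cc(F)cc3c1OCOC3)CC(=O)N2`, which in this assay gives 30 nM; the step between them is a 1.6-fold higher number from compound 1 to compound 3 (0.19 log units; within the scatter). The furthest is compound 2, `Cc1nn(-c2ncnc3nc[nH]c23)c2c1C(c1ccc(F)cc1Cl)CC(=O)N2`, which gives 280 nM, a gap described by a 6.0-fold lower number from compound 2 to compound 3 (0.78 log units; beyond the scatter).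

Compound 4, `Cc1nn(-c2ncnc3nc[nH]c23)c2c1C(OCCn1cccn1)CC(=O)N2`, has not yet been measured. It differs from compound 3 in one place: (1H-pyrazol-1-yl)methyl in place of 2-chlorophenyl on a saturated chain carbon bound to an oxygen on a saturated carbon.

Going by the values given here, of the measured steps, only the one from compound 1 to compound 3 touches the same saturated chain carbon bound to an oxygen on a saturated carbon, and there the exchange of one aromatic group for another was a 1.6-fold higher number from compound 1 to compound 3 (0.19 log units; within the scatter), so within the scatter. The step from compound 2 to compound 3 alters a different part of the molecule and says little here. The group entering in compound 4 is smaller and carries two hydrogen-bond acceptors in place of a six-membered aromatic ring of carbon only, so a wider spread of outcomes seems possible. For compound 4 the expected step is a 2.6-fold higher number from compound 3 to compound 4 (0.41 log units; beyond the scatter). The estimate for compound 4 in this assay is therefore 120 nM, with a range from 30 nM to 500 nM.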

Compound 4, half-maximal effective concentration: 2270 nM
The estimate for compound 4 lay 19-fold (1.28 log units) below the measured number; the whole stated range lies below it.
By their numbers in this assay, from the lowest: compounds 1 and 3 (each within the scatter of the next); then compound 2; then compound 4.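

In this assay, the earlier exchange at the saturated chain carbon bound to an oxygen on a saturated carbon, a 1.6-fold higher number from compound 1 to compound 3 (0.19 log units; within the scatter), left open whether this place responds to change at all, and the new result shows that it does: replacing 2-chlorophenyl with (1H-pyrazol-1-yl)methyl gives a 48-fold higher number from compound 3 to compound 4 (1.68 log units; beyond the scatter), and the comparison with the larger group of compound 1 gives a 76-fold higher number from compound 1 to compound 4 (1.88 log units; beyond the scatter). The oxygen-linked side chain therefore does not secure a low number by itself, since exchanging the 2-chloro-4-fluorophenyl on the saturated ring carbon for 2-(1H-pyrazol-1-yl)ethoxy gives an 8.1-fold higher number from compound 2 to compound 4 (0.91 log units; beyond the scatter), which reverses the direction seen when (2-chlorobenzyl)oxy enters at that carbon. No measurement shown here explains the size of these steps.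

Compound 4 changes the ring and the length of the chain together, so the compounds shown cannot assign the rise in the number to either change alone. A 2-phenylethyl group on the same oxygen, or a pyrazolylmethyl group on it, would separate the two.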